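The source may report more compounds than this note shows. Statements on the series, on what has been measured and on what is new or still open speak of the compounds shown alone.

Measured in a physicochemical assay for lipophilicity; a lower number here means a more polar compound, a higher number a more lipophilic compound:
compound 1 `COC(C)(C)CCCC(C)C/C=C/C(C)=C/C(=O)OC(C)(C)C`: 6.36
compound 2 `COC(C)(C)CCCC(C)C/C=C/C(C)=C/C(=O)OC1CC1`: 5.71

Of these two, compound 2 stands lowest in this assay at 5.71, and its nearest neighbour is compound 1 at 6.36. Compound 3 `COC(C)(C)CCCC(C)C/C=C/C(C)=C/C(=O)SC` differs from compound 2 by a single change: methylsulfanyl in place of cyclopropyloxy on a carbonyl carbon. Within the data shown here, only one measured step bears on this, and only loosely: a number 0.65 log units lower from compound 1 to compound 2 (beyond the scatter), a modest step beyond the scatter in which cyclopropyl replaced tert-butyl. Among the measured compounds shown here, no measured compound carries methylsulfanyl, so that step offers a scale for the change but no firm direction. A smaller step is expected in this assay, slightly downward and probably within the scatter. The estimated step is a number 0.16 log units lower from compound 2 to compound 3 (within the scatter). For compound 3 the expected value is 5.55, with an estimated range from 5.1 to 6.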

Compound 3, partition coefficient: 6.24
Compound 3: the middle estimate sits 0.69 log units below what was measured; the measured number lies above the stated range.
By their numbers in this assay, from the lowest: compound 2; then compounds 3 and 1 (each within the scatter of the next).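

In this assay the change at this carbonyl carbon gives a number 0.53 log units higher from compound 2 to compound 3 (beyond the scatter), showing that the position responds to a group attached through sulfur as well as to those attached through oxygen, and that methylsulfanyl, despite having fewer heavy atoms than cyclopropyloxy, does not bring a lower number. The second comparison, methylsulfanyl in place of tert-butoxy, gives a number 0.12 log units lower from compound 1 to compound 3 (within the scatter) and so does not separate these two groups, which means that heavy-atom count does not order the three compounds. No supporting information explains either step.

The compounds shown leave open how a group attached through nitrogen, such as methylamino, would read at this carbonyl carbon. As far as these compounds go, a free carboxylic acid there also remains open.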